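The compounds below may be only part of what the source reports. "The series", "measured", "known", "first", "only" and "open" are said of these compounds alone.

Three compounds have been measured in a functional assay on A549 cells (Homo sapiens) for cytotoxicity, read by MTT assay, with a stated time of 72 h; a lower number here means a stronger inhibitor, a higher number a weaker inhibitor:

compound 1, `COc1ccc(/C=N/NC(=O)Nc2ccc(Oc3ccnc4cc(OCCCN5CCCCC5)c(OC)cc34)c(F)c2)cc1`, gives 540 nM;
compound 2, `COc1cc2c(Oc3ccc(NC(=O)N/N=C/c4ccc(C(F)(F)F)cc4)cc3F)ccnc2cc1OCCCN1CCCCC1`, gives 660 nM;
compound 3, `COc1ccc(/C=N/NC(=O)Nc2ccc(Oc3ccnc4cc(OCCCN5CCC(C)CC5)c(OC)cc34)c(F)c2)cc1`, gives 430 nM.

Compound 3 has the lowest of the three numbers in this assay, but the step from compound 1 to compound 3, a 1.3-fold lower number from compound 1 to compound 3 (0.10 log units; within the scatter), is within the scatter, and the values of compound 3 and compound 2 also lie within the scatter of each other, so none of the three can be called the strongest inhibitor on this evidence.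

Compound 4, `COc1cc2c(Oc3ccc(NC(=O)N/N=C/c4ccc(C(F)(F)F)cc4)cc3F)ccnc2cc1OCCCN1CCC(C)CC1`, follows from compound 3 by trifluoromethyl in place of methoxy on an aromatic carbon. Among the measured compounds shown here, the one measured step that bears on this change is the one from compound 1 to compound 2, which carries the same swap on the same aromatic ring while the saturated ring carbon still bears hydrogen: a 1.2-fold higher number from compound 1 to compound 2 (0.09 log units; within the scatter). Nothing in the set ties that swap to the methyl on the saturated ring, and that methyl itself moved the number only within scatter in the step from compound 1 to compound 3. For compound 4 in this assay, then, no step beyond the scatter is expected, with at most a slight lean toward a higher number, and the expected step is a 1.2-fold higher number from compound 3 to compound 4 (0.09 log units; within the scatter). Compound 4 is accordingly estimated at 530 nM, with a range from 300 nM to 950 nM.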

Compound 4, half-maximal inhibitory concentration: 650 nM
For compound 4 the middle estimate is 1.2-fold (0.09 log units) below the measured one; the range from low to high includes it.
By their numbers in this assay, from the lowest: compounds 3, 1, 4 and 2 (each within the scatter of the next).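

Among the compounds shown here, on the core that carries the methyl on the saturated ring, the change from 4-methoxyphenyl to 4-(trifluoromethyl)phenyl in this assay gives a 1.5-fold higher number from compound 3 to compound 4 (0.18 log units; within the scatter) and so stays within the scatter on a second core, which the earlier compounds could not show: the same change on two cores in this assay, a 1.2-fold higher number (0.09 log units; within the scatter) from compound 1 to compound 2 and a 1.5-fold higher number (0.18 log units; within the scatter) from compound 3 to compound 4, 1.2-fold (0.09 log units) apart, within the scatter of two such steps. The methyl in place of hydrogen on the saturated ring can now also be read on the core bearing trifluoromethyl, where it gives a 1.0-fold lower number from compound 2 to compound 4 (0.01 log units; within the scatter) and again stays within the scatter: the same change on two cores in this assay, a 1.3-fold lower number (0.10 log units; within the scatter) from compound 1 to compound 3 and a 1.0-fold lower number (0.01 log units; within the scatter) from compound 2 to compound 4, 1.2-fold (0.09 log units) apart, within the scatter of two such steps. Each change has thus been read on two cores, and neither reading moves the number beyond the scatter, so these four compounds give no sign that the effect of one change depends on the other.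

Going by these compounds, whether a nitrile, a hydroxyl or a dimethylamino group on that aromatic carbon would move the number beyond the scatter remains open, as does the effect of an ethyl group or a longer chain in place of the methyl on the saturated ring. With every step here inside the scatter, the compounds shown do not settle which part of the structure governs the number in this assay at all.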